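This account rests on a few compounds, and the source may have more. Where it says the series, first, only, none or still open, it means among the compounds named here.

Measured compounds in a functional assay on HFL1 cells for antagonist activity at sphingosine 1-phosphate receptor 2 (Homo sapiens), read by ELISA, with a stated time of 24 h, in the presence of a further agent that is not named here; on this read-out higher numbers stand for weaker inhibition and lower numbers for stronger inhibition:
- compound 1 `O=C(O)Cn1nc(Cc2cn3cc(OCC4CC4)c(Cl)cc3n2)c2ccccc2c1=O`: 275 nM
- compound 2 `O=C(O)Cn1nc(Cn2cc3cc(OCC4CC4)c(Cl)cc3n2)c2ccccc2c1=O`: 647 nM

Within the data shown here, of the two numbers, the one for compound 2 is the higher; the gap to compound 1 lies beyond the usual scatter, so compound 2 shows the weaker inhibition of the pair. Among the measured compounds shown here, no single-point step between the measured compounds is available, so the effect of the change described next rests on no precedent.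

Compound 3 `C[C@H](C(=O)O)n1nc(Cn2cc3cc(OCC4CC4)c(Cl)cc3n2)c2ccccc2c1=O` differs from compound 2 by methyl in place of hydrogen on a saturated chain carbon bound to an aromatic nitrogen and a carbonyl carbon. With nothing measured for this kind of change, the expected step from compound 2 to compound 3, a 1.1-fold lower number from compound 2 to compound 3 (0.03 log units; within the scatter), is taken to be small and within the scatter, in no fixed direction. Compound 3 is therefore expected to give about 600 nM in this assay, with a range from 220 nM to 1700 nM.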

Compound 3, half-maximal inhibitory concentration in the sphingosine 1-phosphate receptor 2 assay: 197 nM
Compound 3: middle estimate off by 3.0-fold (0.48 log units), on the high side; the whole stated range lies above it.
By their numbers in the sphingosine 1-phosphate receptor 2 assay, from the lowest: compounds 3 and 1 (each within the scatter of the next); then compound 2.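

Among these compounds, in the sphingosine 1-phosphate receptor 2 assay, compound 2 gives 647 nM and compound 3 gives 197 nM; methyl in place of hydrogen on a saturated chain carbon bound to an aromatic nitrogen and a carbonyl carbon gives a 3.3-fold lower number from compound 2 to compound 3 (0.52 log units; beyond the scatter), the first single-point step, and it shows that this position responds to substitution beyond the scatter. In a physicochemical assay for lipophilicity, at pH 7.4 (a higher number here means a more lipophilic compound, a lower number a more polar compound), compound 2 gives 2.79 and compound 3 gives 2.99; the same change, carboxymethyl to 1-carboxyethyl, gives a number 0.20 log units higher from compound 2 to compound 3 (within the scatter). Nothing at hand accounts for the step.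

From the compounds shown here alone, it remains open how the opposite configuration at this carbon would read, and whether ethyl or a second methyl there would extend the step, keep it or lose it. Going by these compounds, it also remains open whether the same methyl would give a similar step on the core of compound 1.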